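Compound 4: a methylphenyl variant of compound 2

The source may report more compounds than this note shows. Statements on the series, on what has been measured and on what is new or still open speak of the compounds shown alone.

Measured so far in a functional assay on A-431 cells (Homo sapiens) for antiproliferative activity, read by MTT assay, with a stated time of 72 h; a higher number here means a weaker inhibitor, a lower number a stronger inhibitor:
compound 1 `COc1cc2ncnc(Nc3ccc(Cl)c(C(F)(F)F)c3)c2cc1OCCCCC(=O)Nc1ccc(S(N)(=O)=O)cc1` gives 3910 nM;
compound 2 `COc1cc2ncnc(Nc3ccc(Br)cc3)c2cc1OCCCCC(=O)Nc1ccc(S(N)(=O)=O)cc1` gives 6570 nM;
compound 3 `COc1ccc(Nc2ncnc3cc(OC)c(OCCCCC(=O)Nc4ccc(S(N)(=O)=O)cc4)cc23)cc1OC` gives 35400 nM.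

Compound 2 stands second highest of the three numbers, close to compound 1 and well apart from compound 3: a 1.7-fold higher number from compound 1 to compound 2 (0.23 log units; within the scatter) is within the scatter, whereas a 5.4-fold higher number from compound 2 to compound 3 (0.73 log units; beyond the scatter) and a 9.1-fold higher number from compound 1 to compound 3 (0.96 log units; beyond the scatter) lie beyond it. Compound 4 `COc1cc2ncnc(Nc3cccc(C)c3)c2cc1OCCCCC(=O)Nc1ccc(S(N)(=O)=O)cc1` carries 3-methylphenyl in place of 4-bromophenyl on a nitrogen on an aromatic ring. Within the data shown here, no measured step replaces the bromophenyl ring with a methyl-bearing ring; the steps that bear on it show the two halogenated rings sitting close together and the dimethoxy ring costing a modest step. A modest step at most is expected, more likely upward than downward. Compound 4 is therefore estimated at 8500 nM (range 3000 nM to 25000 nM), which means a 1.3-fold higher number from compound 2 to compound 4 (0.11 log units; within the scatter) is expected.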

Compound 4, half-maximal inhibitory concentration: 7460 nM
Compound 4: the middle estimate sits 1.1-fold (0.06 log units) above what was measured; the range from low to high includes it.
By their numbers in this assay, from the lowest: compounds 1, 2 and 4 (each within the scatter of the next); then compound 3.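

With 3-methylphenyl on the nitrogen, no halogen is needed for the number to stay in the range of the halogenated rings: a 1.1-fold higher number from compound 2 to compound 4 (0.06 log units; within the scatter) and a 1.9-fold higher number from compound 1 to compound 4 (0.28 log units; within the scatter) are both within the scatter. The 3,4-dimethoxyphenyl ring alone stands apart among the four, with a 4.7-fold lower number from compound 3 to compound 4 (0.68 log units; beyond the scatter) beyond the scatter. No measurement here explains this. Open, from the compounds shown here alone, is whether a phenyl ring bearing an amine or a carboxylic acid would stay with compound 1, compound 2 and compound 4 or move toward compound 3.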